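A few compounds are considered here, and "the series" means these few. Any claim that something is new, unique, unknown or untested is made for them only; others in the source may bear on it.

In a physicochemical assay for lipophilicity, at pH 7.4 (a lower number here means a more polar compound, a higher number a more lipophilic compound), compound 1 `Cc1[nH]c2ccccc2c(=O)c1Br` gives 1.67 and compound 2 `COc1ccc2[nH]c(C)c(Br)c(=O)c2c1` gives 1.62 while compound 3 `Cc1ccc2[nH]c(C)c(Br)c(=O)c2c1` gives 1.07 as the lowest of the three numbers. Compound 4 `Cc1[nH]c2ccc(Br)cc2c(=O)c1Br` differs from compound 3 by bromo in place of methyl on an aromatic carbon with bromo in place of methyl on an aromatic carbon. For the measured compounds named here, two measured steps bear on this methyl: a number 0.60 log units lower from compound 1 to compound 3 (beyond the scatter) and a number 0.55 log units lower from compound 2 to compound 3 (beyond the scatter) as modest steps of similar size. Going by these two steps, a rise of about the same size is expected in this assay once methyl leaves, although no measured step yet shows what bromo itself does. The estimated step is a number 0.63 log units higher from compound 3 to compound 4 (beyond the scatter) in this reading. For compound 4 the expected value is 1.7 with 1.2 and 2.3 as the ends of the estimated range.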

Compound 4, distribution coefficient: 1.76
Beside the measured number, compound 4's estimate is 0.06 log units below it; the measured number falls inside the stated range.
By their numbers in this assay, from the lowest: compound 3; then compounds 2, 1 and 4 (each within the scatter of the next).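

In this assay, bromo on this aromatic carbon does not follow methyl: a number 0.69 log units higher from compound 3 to compound 4 (beyond the scatter), while a number 0.14 log units higher from compound 2 to compound 4 (within the scatter) and a number 0.09 log units higher from compound 1 to compound 4 (within the scatter). Among the four compounds, hydrogen, methoxy and bromo at this place therefore read alike, and only the methyl of compound 3 stands apart. No measured evidence accounts for this difference.

Going by these compounds, whether an amine or a carboxylic acid here would read like those three groups or like methyl remains open. So does whether a longer chain would follow methyl.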